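Dienone series: aryl swap at the chain terminus

A few compounds are considered here, and "the series" means these few. Any claim that something is new, unique, unknown or untested is made for them only; others in the source may bear on it.

compound 1: `O=C(/C=C/c1ccc(Cl)c([N+](=O)[O-])c1)/C=C/c1ccccc1Oc1ncnc2ccc(Cl)cc12` — 5320 nM
compound 2: `O=C(/C=C/c1ccccc1Oc1ncnc2ccc(Cl)cc12)/C=C/c1cccc(Cl)c1Cl` — 5210 nM
compound 3: `O=C(/C=C/c1ccc(Oc2ncnc3ccc(Cl)cc23)cc1)/C=C/c1c(Cl)cccc1Cl` — 6770 nM

In a functional assay on MGC-803 cells (Homo sapiens) for inhibition, read by MTT assay, with a stated time of 72 h (on this read-out lower numbers stand for stronger inhibition and higher numbers for weaker inhibition), compound 2 gives the lowest number of the three, yet it lies within the scatter of both compound 1 and compound 3, so no order among them can be claimed. Compound 4, `O=C(/C=C/c1ccc(Cl)c(Cl)c1)/C=C/c1ccccc1Oc1ncnc2ccc(Cl)cc12`, differs from compound 2 by 3,4-dichlorophenyl in place of 2,3-dichlorophenyl on a double-bonded chain carbon bound to a double-bonded chain carbon. Within the data shown here, the only measured step at this place is a 1.0-fold lower number from compound 1 to compound 2 (0.01 log units; within the scatter), a change of the aryl group on the same chain carbon that left the read-out unchanged. Among the measured compounds shown here, with only that precedent, no step beyond the scatter is expected for a 1.1-fold higher number from compound 2 to compound 4 (0.02 log units; within the scatter). Compound 4 is therefore expected to give 5500 nM, with a range from 2700 nM to 11000 nM in this assay.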

Compound 4, half-maximal inhibitory concentration: 16200 nM
For compound 4 the middle estimate is 2.9-fold (0.47 log units) below the measured one, outside the stated range (above it).
By their numbers in this assay, from the lowest: compounds 2, 1 and 3 (each within the scatter of the next); then compound 4.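

In this assay the aryl group on this chain carbon is no longer indifferent: with the same atoms, the change from 2,3-dichlorophenyl to 3,4-dichlorophenyl gives a 3.1-fold higher number from compound 2 to compound 4 (0.49 log units; beyond the scatter) and lies beyond the scatter, unlike the earlier swap at this place. Chloro in place of nitro on an aromatic carbon gives a 3.0-fold higher number from compound 1 to compound 4 (0.48 log units; beyond the scatter) as well, so compound 4 alone stands apart from compound 1 and compound 2. No measurement shown offers an explanation for these steps.

Open, as far as these compounds go, is whether an amine or a carboxylic acid on this aryl group would read with compound 2 or with compound 4. Also open, from the compounds shown here alone, is whether 3,4-dichlorophenyl would give a similar step on the core of compound 3.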